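The source may hold more compounds than are shown below. What is called first, only, known or untested is meant among the compounds shown, and "the series" means these compounds.

In a functional assay on A-375 cells (Homo sapiens) for inhibition, read by MTT assay, with a stated time of 120 h (on this read-out higher numbers stand for weaker inhibition and lower numbers for stronger inhibition), compound 1 `CC(NC(=O)C#Cc1ccc(NC(=O)Nc2cc(C(F)(F)F)ccc2Cl)cc1)c1ccccc1` gives 30500 nM and compound 2 `CC(NC(=O)C#Cc1ccc(NC(=O)Nc2ccc(Cl)c(C(F)(F)F)c2)cc1)c1ccccc1` gives 16800 nM. The step of a 1.8-fold lower number from compound 1 to compound 2 (0.26 log units; within the scatter) leaves these two values level, so compound 2 stands with compound 1 and apart from neither. Compound 3 `CC(NC(=O)CCc1ccc(NC(=O)Nc2ccc(Cl)c(C(F)(F)F)c2)cc1)c1ccccc1` reports only a limit, > 50000 nM.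

The next compound is compound 4 `CNC(=O)C#Cc1ccc(NC(=O)Nc2ccc(Cl)c(C(F)(F)F)c2)cc1`, which differs from compound 2 by methyl in place of 1-phenylethyl on an amide-type nitrogen. For the measured compounds named here, no measured step touches this group. Going by the values given here, the one measured step, a 1.8-fold lower number from compound 1 to compound 2 (0.26 log units; within the scatter), changes a different part of the molecule and offers only a weak guide, since it stays within the scatter. With compound 2 at 16800 nM, there is also little room before (the limit of > 50000 nM in this assay, at which 1 of the 3 values shown sits). A small rise in the number is therefore expected, though with wide uncertainty, and the estimate is a 1.8-fold higher number from compound 2 to compound 4 (0.25 log units; within the scatter). For compound 4 the expected value is 30000 nM, within an estimated range of 12000 nM to 75000 nM.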

Compound 4, half-maximal inhibitory concentration: > 50000 nM
Compound 4: no number, only a limit; the forecaster's own chance of this, stated with the estimate: 35%; middle value at least 1.6-fold (0.22 log units) from the limit.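

Replacing 1-phenylethyl with methyl on the amide-type nitrogen gives an at least 2.9-fold higher number from compound 2 to compound 4 (0.47 log units; beyond the scatter) in this assay, so this is the first change shown to move the read-out beyond the scatter, whereas the earlier measured step, in a different part of the molecule, did not. Compound 4 reports > 50000 nM, which is a limit and not a number. The step therefore fixes only the direction and a minimum size for this change, and the true size stays unknown: the limit of > 50000 nM in this assay, at which 2 of the 4 values shown sit.

From the compounds shown here alone, it remains open whether the aromatic ring of 1-phenylethyl or some other part of that group accounts for the difference, which a benzyl or cyclohexyl group on the same nitrogen could help to separate. A longer chain such as butyl could show whether a simple alkyl group behaves like methyl at this position.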